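Replacing the Carboxylic Acid in a Pyrrolidine Amide Series

This account rests on a few compounds, and the source may have more. Where it says the series, first, only, none or still open, it means among the compounds named here.

Compound 1 `O=C(CCCCCCc1ccc(Cl)cc1)N1CCCC1`: in an assay on HEK293 cells for inhibition of N-acylethanolamine-hydrolyzing acid amidase (Rattus norvegicus), read by LC-MS, with a stated time of 30 min (on this read-out lower numbers stand for stronger inhibition and higher numbers for weaker inhibition), compound 1 gives 34500 nM.
Compound 2 `O=C(O)c1ccc(CCCCCCC(=O)N2CCCC2)cc1`: in this assay compound 2 gives only a limit, > 100000 nM.

Compound 2 carries a carboxy group on the aromatic ring and sits at the weak end of the two measured values, where the assay reports no number but only a limit, as stated by the limit of > 100000 nM in this assay, at which 1 of the 2 values shown sits. Among the measured compounds shown here, the only measured step is an at least 2.8-fold higher number from compound 1 to compound 2 (0.46 log units; beyond the scatter), which shows that exchanging chloro for carboxy weakened inhibition beyond the scatter. Compound 3 `CCCc1ccc(CCCCCCC(=O)N2CCCC2)cc1` carries the change (propyl in place of carboxy on an aromatic carbon). For the measured compounds named here, since the carboxy group is the one feature that distinguishes compound 2 from the stronger compound 1, removing it is expected to bring inhibition back to about the level of compound 1, so the step is estimated as an at least 4.0-fold lower number from compound 2 to compound 3 (0.60 log units; beyond the scatter). Compound 3 is therefore expected to give 25000 nM in this assay, with a range from 7000 nM to 90000 nM.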

Compound 3, half-maximal inhibitory concentration: > 100000 nM
Compound 3 ended at the assay's limit; the forecaster's own chance of this, stated with the estimate: 15%; middle value at least 4.0-fold (0.60 log units) from the limit.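

Removing the carboxy group did not by itself bring inhibition back: with propyl on the same aromatic carbon, this assay shows an at least 2.8-fold higher number from compound 1 to compound 3 (0.46 log units; beyond the scatter). So the weak end of this series is not tied to the carboxy group alone, since two quite different groups at this position, one with a hydrogen-bond donor and one made of carbon only, both give weaker inhibition than chloro. Whether propyl improves on carboxy at all cannot be read, because both compounds sit at the limit: the limit of > 100000 nM in this assay, at which 2 of the 3 values shown sit.

Among the compounds shown here, compound 1 remains the only compound here with a true number, so what this position tolerates rests on chloro alone. Going by these compounds, whether bromo, fluoro, methyl or methoxy on this aromatic carbon would keep inhibition within the measurable range stays open.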